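Trifluoromethyl for chloro: a small step expected

The source may report more compounds than this note shows. Statements on the series, on what has been measured and on what is new or still open speak of the compounds shown alone.

In a functional assay on NB-4 cells (Homo sapiens) for cytotoxicity, read by CCK-8 assay, with a stated time of 24 h (on this read-out higher numbers stand for weaker inhibition and lower numbers for stronger inhibition), compound 2 (`C=CC(=O)N1C(=O)CC(c2ccccc2Cl)Sc2ccccc21`) gives 33800 nM as its value. Going by the values given here, its only measured neighbour, compound 1 (`C=CC(=O)N1C(=O)CC(c2ccc(OC)cc2)Sc2ccccc21`), gives 32900 nM as its value, and the two lie within the usual scatter of each other. The next compound, compound 3 (`C=CC(=O)N1C(=O)CC(c2ccccc2C(F)(F)F)Sc2ccccc21`), has trifluoromethyl in place of chloro on an aromatic carbon, and the rest of the structure stays the same. Among the compounds with values here, only one measured step bears on this change. That step, a 1.0-fold higher number from compound 1 to compound 2 (0.01 log units; within the scatter), replaced 4-methoxyphenyl with 2-chlorophenyl on a saturated ring carbon and stayed within the scatter. Two compounds are thin evidence, but they give no reason to expect a real shift in this assay here. The expected change, a 1.0-fold lower number from compound 2 to compound 3 (0.01 log units; within the scatter), is no larger than the scatter. For compound 3 the estimated value is 33000 nM, with an expected range from 15000 nM to 70000 nM in this test.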

Compound 3, half-maximal inhibitory concentration: 35200 nM
Beside the measured number, compound 3's estimate is 1.1-fold (0.03 log units) below it; low and high end bracket the measured number.
By their numbers in this assay, from the lowest: compounds 1, 2 and 3 (each within the scatter of the next).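

In this assay, trifluoromethyl in place of chloro gave a 1.0-fold higher number from compound 2 to compound 3 (0.02 log units; within the scatter) and so made no difference that can be told from scatter. The earlier step swapped one whole substituted phenyl group for another, whereas this one changes a single group on an aromatic carbon, ortho to a large group. Here, trifluoromethyl with 4 heavy atoms and chloro with 1 heavy atom give readings within the scatter of each other, so this change in size does not show up in this cell test.

As far as these compounds go, whether an amine or a carboxylic acid at this place would also read the same remains open. Nothing measured here explains why chloro and trifluoromethyl read alike at this position.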